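The source may hold more compounds than are shown below. What is called first, only, known or untested is meant among the compounds shown, and "the series" means these compounds.

Measured compounds:
Compound 1, `Cc1ccc(NC(=O)Nc2cc(C(C)(C)C)nn2-c2ccccc2)cc1`, gives 4.6 degrees C in an assay on isolated protein for inhibition of STE20-like serine/threonine-protein kinase (Homo sapiens), read by thermal shift assay, tested at 10 uM; on this read-out lower numbers stand for weaker stabilisation of the target and higher numbers for stronger stabilisation of the target against heat.
Compound 2, `Cc1ccc(-n2nc(C(C)(C)C)cc2NC(=O)Nc2cc(C(F)(F)F)cc(C(F)(F)F)c2)cc1`, gives 0 degrees C in this assay.

Of the two numbers, compound 2 holds the lower one; compound 1 lies a good deal higher, and that gap is beyond the usual scatter of repeated measurements. Compound 1 and compound 2 differ in several places at once, so nothing can be said about which part of that difference matters.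

Compound 3, `CC(C)(C)c1cc(NC(=O)Nc2cc(C(F)(F)F)cc(C(F)(F)F)c2)n(-c2ccc(Br)cc2)n1`, has not yet been measured. It departs from compound 2 by a single change, (bromo in place of methyl on an aromatic carbon), that is, bromo in place of methyl on an aromatic carbon, with the rest of the molecule kept as it is.

No single-change comparison among the measured compounds is available to show what such a swap does here, so the expectation rests on compound 2 alone. A small step is expected, a number 1.0 degrees C higher from compound 2 to compound 3 (within the scatter), within or close to the scatter. Compound 3 is therefore estimated at 1 degrees C, with a likely range from -1 degrees C to 3.5 degrees C.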

Compound 3, shift of the target's melting temperature: 0.1 degrees C
For compound 3 the middle estimate is 0.90 degrees C above the measured one, within the range that was stated.
By their numbers in this assay, from the lowest: compounds 2 and 3 (each within the scatter of the next); then compound 1.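

In this assay, going from 4-methylphenyl to 4-bromophenyl gives a number 0.10 degrees C higher from compound 2 to compound 3 (within the scatter), the first single-change comparison available for these compounds. At this place on the six-membered aromatic ring, para to a large group, bromo therefore does not give a number that can be told apart from the one given by methyl, and compound 3, at 0.1 degrees C, still shows almost no stabilisation of the target. There is no supporting information that could explain this result.

Going by these compounds, since both numbers lie close to zero, it remains open whether methyl and bromo would also match on a compound with a clearly higher number, such as compound 1 at 4.6 degrees C, which differs from compound 2 in several places at once. On these data alone, it is also open whether a group of another kind at this place, such as an amine or a carboxylic acid, would move the number in this assay at all, or whether the parts of the molecule that compound 2 and compound 3 share hold the number near zero.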